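The compounds below may be only part of what the source reports. "The series", "measured", "known", "first", "only" and "open" are said of these compounds alone.

In an assay on isolated protein for inhibition of Fatty-acid amide hydrolase 1 (Rattus norvegicus), with a stated time of 3 h (a higher number here means a weaker inhibitor, a lower number a stronger inhibitor), the measured compounds are these. Compound 1 `Cc1cnn(C(=O)OCCCCc2ccccc2)c1` gives > 5000 nM, which is a limit of the assay and not a number. Compound 2 `N#Cc1cnn(C(=O)OCCCCc2ccccc2)c1` gives 210 nM. Compound 3 `Cc1cnn(C(=O)CCCCCc2ccccc2)c1` gives > 5000 nM, again a limit of the assay rather than a number.

From compound 1 to compound 2 the change is cyano in place of methyl on an aromatic carbon. That change made an at least 23-fold lower number from compound 1 to compound 2 (1.37 log units; beyond the scatter). How the core of compound 1 and the core of compound 3 differ is not broken down here. Compound 4 `N#Cc1cnn(C(=O)CCCCCc2ccccc2)c1` has not yet been measured; it is built from compound 3 by cyano in place of methyl on an aromatic carbon, the same change, at the same place, as from compound 1 to compound 2.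

Going by the values given here, two of the three values so far sit at the limit of > 5000 nM in this assay, at which 2 of the 3 values shown sit, so the starting point of the new step is known only as a limit, and the step itself can only be expected, not computed, from the first pair. Because of an at least 23-fold lower number from compound 1 to compound 2 (1.37 log units; beyond the scatter) the step is expected to be an at least 3.3-fold lower number from compound 3 to compound 4 (0.52 log units; beyond the scatter). For compound 4 the estimated value in this assay is 1500 nM, expected to lie between 300 nM and 8000 nM.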

Compound 4, inhibition constant: > 5000 nM
Compound 4: only a limit was reported (the forecaster's own chance of this, stated with the estimate: 40%); middle value at least 3.3-fold (0.52 log units) away from the limit.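

In this assay, compound 3 and compound 4 both give a limit of the assay rather than a number, so no step can be read between them: the limit of > 5000 nM in this assay, at which 3 of the 4 values shown sit.

Still open, going by these compounds, is whether cyano in place of methyl changes the number at all on the core of compound 3, as it does on the core of compound 1.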